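Swapping a pyridinyloxy for a pyridinyloxymethyl and cell tolerance

The compounds below may be only part of what the source reports. "The series", "measured", "known", "first", "only" and "open" are said of these compounds alone.

Measured compounds and their values:
compound 1 `Fc1cccc(F)c1Cc1cnc(Nc2ccc(Oc3ccncc3)c(Cl)c2)o1`: 21000 nM
compound 2 `OCCc1ccc(Nc2ncc(Cc3c(F)cccc3F)o2)cc1`: 35000 nM
compound 3 `Fc1cccc(F)c1Cc1cnc(Nc2ccc(Oc3ccncc3)cc2)o1`: 21000 nM

In an ADME assay on MT2 cells (Homo sapiens) for cytotoxicity, read by MTT assay (a lower number here means that less compound is tolerated, a higher number that more compound is tolerated), compound 1 gives 21000 nM. It stands level with compound 3 and is, together with compound 3, at the lowest of the three numbers; the gap to compound 2 lies within the scatter, so no order among the three can be claimed.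

Compound 4 `Fc1cccc(F)c1Cc1cnc(Nc2ccc(COc3ccncc3)c(Cl)c2)o1` is not yet measured. It differs from compound 1 in one place: ((pyridin-4-yl)oxy)methyl in place of (pyridin-4-yl)oxy on an aromatic carbon.

Within the data shown here, two measured steps touch this part of the shared core. The step of no change at the digits printed from compound 1 to compound 3 (within the scatter) removes the chloro group and leaves the number unchanged. The step of a 1.7-fold lower number from compound 2 to compound 3 (0.22 log units; within the scatter) replaces the whole group at this position and also stays within the scatter. Both changes near the position leave cell tolerance essentially untouched, so a step of no size beyond the scatter is expected for compound 4 in this assay, and the expected step is no change at the digits printed from compound 1 to compound 4 (within the scatter).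

Compound 4 is therefore estimated at 21000 nM, with a range from 10000 nM to 45000 nM.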

Compound 4, half-maximal cytotoxic concentration: 3800 nM
The estimate for compound 4 lay 5.5-fold (0.74 log units) above the measured number; the whole stated range lies above it.
By their numbers in this assay, from the lowest: compound 4; then compounds 1, 3 and 2 (each within the scatter of the next).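

In this assay, putting ((pyridin-4-yl)oxy)methyl in place of (pyridin-4-yl)oxy gives a 5.5-fold lower number from compound 1 to compound 4 (0.74 log units; beyond the scatter), so less compound is tolerated even though both groups hold the same one six-membered aromatic ring and the same counts of hydrogen-bond donors and acceptors. The earlier steps, no change at the digits printed from compound 1 to compound 3 (within the scatter) and a 1.7-fold lower number from compound 2 to compound 3 (0.22 log units; within the scatter), stayed within the scatter, so this position looked indifferent until this change, the first among the compounds shown to move the number beyond the scatter. Nothing given here explains why the number falls.

As far as these compounds go, whether the same step would appear without the chloro group remains open. So does the question of whether a longer chain, or an amine in place of the oxygen in this group, would take the number further down or bring it back.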